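A few compounds are considered here, and "the series" means these few. Any claim that something is new, unique, unknown or untested is made for them only; others in the source may bear on it.

Compound 3 `NC(=O)CC[C@H](NC(=O)CN(c1nc(Cl)nc2[nH]cnc12)C1CC1)C(=O)OCc1ccccc1` gives 31.1% in a functional assay on the whole organism (Tail, strain ICR) with Mus musculus as the target, in the tail flick test, with a stated time of 150 min, at a dose of 25 umol/kg by the oral route (a higher number here means a stronger effect of the compound at the dose given, a lower number a weaker effect), the highest of the three numbers in hand; compound 2 `C[C@H](NC(=O)CN(c1nc(Cl)nc2[nH]cnc12)C1CC1)C(=O)OCc1ccccc1` gives 23%, and compound 1 `CSCC[C@H](NC(=O)CN(c1nc(Cl)nc2[nH]cnc12)C1CC1)C(=O)OCc1ccccc1` gives 17.6%. Going by the values given here, only the step of a number 13.5 percentage points higher from compound 1 to compound 3 (beyond the scatter) lies beyond the scatter, whereas a number 5.4 percentage points higher from compound 1 to compound 2 (within the scatter) and a number 8.1 percentage points higher from compound 2 to compound 3 (within the scatter) do not. Compound 4 `O=C(CN(c1nc(Cl)nc2[nH]cnc12)C1CC1)N[C@@H](CO)C(=O)OCc1ccccc1` differs from compound 3 by hydroxy in place of carbamoylmethyl on a saturated chain carbon, two bonds along the chain from an amide-type nitrogen and a carbonyl carbon. Among the compounds with values here, the one measured step that touches this place is a number 8.1 percentage points higher from compound 2 to compound 3 (within the scatter), which keeps the gain from the carbamoylmethyl group within the scatter; no measured step shows what hydroxy at this place does. A step within the scatter is therefore expected, a number 6.1 percentage points lower from compound 3 to compound 4 (within the scatter), and compound 4 is estimated to give 25%, between 12% and 38%.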

Compound 4, a percentage reported as activity, at one dose (the size of the read-out at that dose, not a potency): 27.9%
Compound 4: the middle estimate sits 2.9 percentage points below what was measured; the measured number falls inside the stated range.
By their numbers in this assay, from the lowest: compounds 1, 2, 4 and 3 (each within the scatter of the next, the first and the last beyond it).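

In this assay, hydroxy at this place cannot be told apart from carbamoylmethyl, with a number 3.2 percentage points lower from compound 3 to compound 4 (within the scatter) as the step, or from hydrogen, with a number 4.9 percentage points higher from compound 2 to compound 4 (within the scatter) as the step. Going by these compounds alone, the one step from compound 4 that clears the scatter is a number 10.3 percentage points higher from compound 1 to compound 4 (beyond the scatter), so compound 1 sits apart from both compound 3 and compound 4, while compound 2 sits apart from neither. Nothing in hand gives a reason for these steps.

On these data alone, an amine, a carboxylic acid or a longer chain bearing hydroxy at this place remains open. So does whether any such group would clear the scatter from compound 2.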